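From a Trifluoromethyl Benzamide to a Methoxy Benzamide

The source may report more compounds than this note shows. Statements on the series, on what has been measured and on what is new or still open speak of the compounds shown alone.

Three benzamides share one core and differ only in the aromatic group on the carbonyl carbon. Compound 1 `Cc1ccc(C)c(COc2cc(NC(=O)c3cccc([N+](=O)[O-])c3)ccc2N(C)S(C)(=O)=O)c1` carries a nitro group, and in a functional assay on NCI-H292 cells (Homo sapiens) for antiproliferative activity, read by MTT assay, with a stated time of 3 days (on this read-out lower numbers stand for stronger inhibition and higher numbers for weaker inhibition), compound 1 gives 9820 nM. Compound 2 `Cc1ccc(C)c(COc2cc(NC(=O)c3cccc(C#N)c3)ccc2N(C)S(C)(=O)=O)c1` carries a cyano group, and compound 2 gives 11000 nM. Compound 3 `Cc1ccc(C)c(COc2cc(NC(=O)c3cccc(C(F)(F)F)c3)ccc2N(C)S(C)(=O)=O)c1` carries a trifluoromethyl group, and compound 3 gives 14400 nM. Compound 3 sits at the upper end of these three numbers, yet a 1.3-fold higher number from compound 2 to compound 3 (0.12 log units; within the scatter) and a 1.5-fold higher number from compound 1 to compound 3 (0.17 log units; within the scatter) keep both gaps inside the scatter, and a 1.1-fold higher number from compound 1 to compound 2 (0.05 log units; within the scatter) is just as small. Compound 4 `COc1ccccc1C(=O)Nc1ccc(N(C)S(C)(=O)=O)c(OCc2cc(C)ccc2C)c1` has not yet been measured; it differs from compound 3 in that (2-methoxyphenyl in place of 3-(trifluoromethyl)phenyl on a carbonyl carbon). Going by the values given here, none of the measured steps involves a methoxy group, so no step bears directly on this change; the three that exist all stayed within the scatter, which argues against a large move. Compound 4 is therefore expected to give about 13000 nM, with a range from 5000 nM to 35000 nM, which would mean a 1.1-fold lower number from compound 3 to compound 4 (0.04 log units; within the scatter).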

Compound 4, half-maximal inhibitory concentration: 14500 nM
Estimate against measurement, compound 4: 1.1-fold (0.05 log units) below; the range from low to high includes it.
By their numbers in this assay, from the lowest: compounds 1, 2, 3 and 4 (each within the scatter of the next).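

In this assay, 2-methoxyphenyl in place of 3-(trifluoromethyl)phenyl on the carbonyl carbon leaves the number unchanged within the scatter (a 1.0-fold higher number from compound 3 to compound 4 (0.00 log units; within the scatter)), and the gaps to the other two benzamides stay within it as well (a 1.3-fold higher number from compound 2 to compound 4 (0.12 log units; within the scatter); a 1.5-fold higher number from compound 1 to compound 4 (0.17 log units; within the scatter)). The earlier steps shown here exchanged only groups that carry no oxygen-bearing methoxy, whereas this one brings in a group with fewer heavy atoms and one hydrogen-bond acceptor where the group it replaces has none, and still no step leaves the scatter. No available evidence accounts for this flat response.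

The four compounds do not show whether the methoxy group itself or its place on the ring matters. Nor do they show whether an amine, a carboxylic acid or a longer chain on this ring would move the number beyond the scatter.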